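Methoxy added to the weakest of three chloro compounds

This account rests on a few compounds, and the source may have more. Where it says the series, first, only, none or still open, it means among the compounds named here.

- Compound 1 `FC(F)(F)c1ccc(/C=C\c2cc3ccccc3nc2Cl)cc1`: 4220 nM
- Compound 2 `COc1ccc2nc(Cl)c(/C=C\c3ccc(C(F)(F)F)cc3)cc2c1`: 16200 nM
- Compound 3 `FC(F)(F)c1ccc(/C=C\c2cc3ccccc3nc2Cl)c(C(F)(F)F)c1`: 35900 nM

In a functional assay on HeLa cells (Homo sapiens) for antiproliferative activity, read by sulforhodamine B assay, with a stated time of 72 h (a lower number here means a stronger inhibitor, a higher number a weaker inhibitor), compound 3 stands highest of the three, making it the weakest inhibitor measured. Compound 4 `COc1ccc2nc(Cl)c(/C=C\c3ccc(C(F)(F)F)cc3C(F)(F)F)cc2c1` differs from it by methoxy in place of hydrogen on an aromatic carbon. The same replacement has been measured once, as a 3.8-fold higher number from compound 1 to compound 2 (0.58 log units; beyond the scatter). The trifluoromethyl replacement, an 8.5-fold higher number from compound 1 to compound 3 (0.93 log units; beyond the scatter), also raised the number, and it separates compound 3 from the parent. On that single methoxy precedent, a modest rise is expected again. The expected step is a 2.5-fold higher number from compound 3 to compound 4 (0.40 log units; beyond the scatter). Compound 4 is estimated at 90000 nM, within an expected range of 30000 nM to 250000 nM.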

Compound 4, half-maximal inhibitory concentration: > 50000 nM
Compound 4 ended at the assay's limit (the forecaster's own chance of this, stated with the estimate: 30%); the middle value lies beyond the limit too.
By their numbers in this assay, from the lowest: compound 1; then compound 2; then compound 3. At a limit, above all of these: compound 4.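

In this assay compound 4 gives > 50000 nM as a limit of the assay and not as a number. Methoxy in place of hydrogen on this aromatic carbon gives an at least 1.3-fold higher number from compound 3 to compound 4 (0.14 log units; that floor lies within the scatter) and so, with that floor within the scatter, does not by itself show a rise on this core. Trifluoromethyl in place of hydrogen gives an at least 3.0-fold higher number from compound 2 to compound 4 (0.48 log units; beyond the scatter) and so raises the number on the methoxy core as well: the same change on two cores in this assay, an 8.5-fold higher number (0.93 log units; beyond the scatter) from compound 1 to compound 3 and an at least 3.0-fold higher number (0.48 log units; beyond the scatter) from compound 2 to compound 4; the limit leaves it open whether they differ.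

On these data alone, how large the methoxy step is on this core stays open: the same change on two cores in this assay, a 3.8-fold higher number (0.58 log units; beyond the scatter) from compound 1 to compound 2 and an at least 1.3-fold higher number (0.14 log units; that floor lies within the scatter) from compound 3 to compound 4; the limit leaves it open whether they differ. As far as these compounds go, whether an amine or a carboxylic acid on this aromatic carbon would lower the number is also open.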